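The source may hold more compounds than are shown below. What is called first, only, known or untested is meant among the compounds shown, and "the series" means these compounds.

Working notes on the series.

Compound 3 `CCCNC(=O)c1cc(Oc2ccc(NC(=O)c3cc4cccnc4n(-c4ccc(Br)cc4F)c3=O)cc2)ccn1` gives 2160 nM in a functional assay on HT-29 cells (Homo sapiens) for antiproliferative activity, read by MTT assay, with a stated time of 72 h; a higher number here means a weaker inhibitor, a lower number a stronger inhibitor. Among the three compounds with numbers, it stands second highest: compound 1 `CNC(=O)c1cc(Oc2ccc(NC(=O)c3cc4cccnc4n(-c4ccc(C(F)(F)F)cc4Cl)c3=O)cc2)ccn1` gives 3190 nM in this assay, a gap to compound 3 within the scatter, while compound 2 `CCCNC(=O)c1cc(Oc2ccc(NC(=O)c3cc4cccnc4n(-c4ccc(F)cc4)c3=O)cc2)ccn1` gives 84 nM. For the measured compounds named here, the one step bearing on the aryl group on the aromatic nitrogen is a 26-fold higher number from compound 2 to compound 3 (1.41 log units; beyond the scatter), a large rise on replacing 4-fluorophenyl with 4-bromo-2-fluorophenyl.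

Compound 4 `CCCNC(=O)c1cc(Oc2ccc(NC(=O)c3cc4cccnc4n(-c4ccc(C(F)(F)F)cc4Cl)c3=O)cc2)ccn1` has not yet been measured. It differs from compound 3 by 2-chloro-4-(trifluoromethyl)phenyl in place of 4-bromo-2-fluorophenyl on an aromatic nitrogen. Going by the values given here, no measured step covers exactly this exchange. Compound 1 carries the same 2-chloro-4-(trifluoromethyl)phenyl group with a methylamide in place of the propylamide, and its number and that of compound 3 lie within the scatter of each other. The expectation for compound 4 in this assay is therefore a step of a 1.2-fold higher number from compound 3 to compound 4 (0.06 log units; within the scatter), that is no change beyond the scatter. Compound 4 is estimated at 2500 nM, with a range from 800 nM to 8000 nM.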

Compound 4, half-maximal inhibitory concentration: 1960 nM
Compound 4: middle estimate off by 1.3-fold (0.11 log units), on the high side, and the stated range covers the measured number.
By their numbers in this assay, from the lowest: compound 2; then compounds 4, 3 and 1 (each within the scatter of the next).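

In this assay the step of a 1.1-fold lower number from compound 3 to compound 4 (0.04 log units; within the scatter) shows that 2-chloro-4-(trifluoromethyl)phenyl and 4-bromo-2-fluorophenyl on the aromatic nitrogen cannot be told apart, while a 23-fold higher number from compound 2 to compound 4 (1.37 log units; beyond the scatter) shows that the large rise from 4-fluorophenyl is not confined to 4-bromo-2-fluorophenyl but recurs with a second aryl group. For the compounds shown here, the first reading on the amide chain, with 2-chloro-4-(trifluoromethyl)phenyl held fixed, is a 1.6-fold lower number from compound 1 to compound 4 (0.21 log units; within the scatter) and places ethyl in place of hydrogen on that chain within the scatter. No measurement to hand accounts for either finding.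

Still open, on these data alone, is which feature of the two larger aryl groups goes with the rise, as unsubstituted phenyl or a lone 4-chlorophenyl would test. Also open, as far as these compounds go, is whether a longer chain or an amine on the amide would shift the number, and whether the chain matters with 4-fluorophenyl in place.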